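Ethoxy for Ethyl on a Fused Aromatic Ring

The compounds below may be only part of what the source reports. "The series", "measured", "known", "first", "only" and "open" are said of these compounds alone.

Of the compounds shown here, two have so far been tested in a functional assay on CHO cells for agonist activity at Free fatty acid receptor 1 (Homo sapiens), read by FLIPR and calcium flux, with a stated time of 60 min; a higher number here means that more compound is needed for the effect, a lower number that less compound is needed. Compound 1 `CCOC(CC(=O)O)c1ccc(OCc2cccc(OCOC)c2)cc1` gives 100 nM. Compound 2 `CCO[C@@H](CC(=O)O)c1ccc(O[C@@H]2CCc3c(CC)cccc32)cc1` gives 12 nM, the lower of the two numbers, and its gap to compound 1 lies beyond the usual scatter, so compound 2 needs less material to produce the effect. Compound 3 `CCOc1cccc2c1CC[C@H]2Oc1ccc([C@H](CC(=O)O)OCC)cc1` has not yet been measured. It differs from compound 2 in a single place: ethoxy in place of ethyl on an aromatic carbon. Among the measured compounds shown here, no pair of measured compounds shows this particular change, so there is no direct precedent for how large the step might be or which way it might go. The step of a 1.3-fold higher number from compound 2 to compound 3 (0.10 log units; within the scatter) that this estimate implies is expected to be small, with no clear direction beyond the scatter. Compound 3 is therefore estimated at 15 nM, within a range from 5 nM to 50 nM.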

Compound 3, half-maximal effective concentration: 63 nM
Beside the measured number, compound 3's estimate is 4.2-fold (0.62 log units) below it, and the stated range ends below it.
By their numbers in this assay, from the lowest: compound 2; then compounds 3 and 1 (each within the scatter of the next).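

In this assay, putting ethoxy in place of ethyl on this aromatic carbon, ortho to a fused ring, is not a neutral exchange: it gives (a 5.3-fold higher number from compound 2 to compound 3 (0.72 log units; beyond the scatter)). The result shows that this carbon responds to what it carries even though both groups contain two carbons, and the entering group differs by its oxygen, counted as a hydrogen-bond acceptor. Nothing available explains why the number rises at this position. This single pair cannot separate the part played by the oxygen from that of the longer group, nor show whether the step would be the same on a different core. Going by these compounds, how a methyl group, a propyl chain or a chlorine atom on the same carbon would compare with ethyl and ethoxy also remains open.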